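A few compounds are considered here, and "the series" means these few. Any claim that something is new, unique, unknown or untested is made for them only; others in the source may bear on it.

Measured compounds:
compound 1 `O=C1O[C@H]([C@@H](O)Cn2cc(CNS(=O)(=O)c3ccc(F)cc3)nn2)C(OCc2ccccc2)=C1OCc1ccccc1` — in a functional assay on A549 cells (Homo sapiens) for antiproliferative activity, read by MTT assay, with a stated time of 72 h (a higher number here means a weaker inhibitor, a lower number a stronger inhibitor), compound 1 gives 22500 nM
compound 2 `COc1ccc(-c2cn(C[C@H](O)[C@H]3OC(=O)C(OCc4ccccc4)=C3OCc3ccccc3)nn2)cc1` — in this assay compound 2 gives 28300 nM

Compound 1 has the lower of the two numbers, but the step of a 1.3-fold higher number from compound 1 to compound 2 (0.10 log units; within the scatter) lies within the scatter, so the two compounds are indistinguishable on these data. Compound 3 `O=C1O[C@H]([C@@H](O)Cn2cc(CNS(=O)(=O)c3ccc(Cl)cc3F)nn2)C(OCc2ccccc2)=C1OCc1ccccc1` differs from compound 1 by 4-chloro-2-fluorophenyl in place of 4-fluorophenyl on a sulfonyl sulfur. No measured step touches this part of the structure: the one step shown alters the group on the triazole ring instead. With nothing to lean on, a step of a 1.1-fold lower number from compound 1 to compound 3 (0.05 log units; within the scatter) within the scatter is expected. Compound 3 is estimated at 20000 nM, in the range 8000 nM to 50000 nM.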

Compound 3, half-maximal inhibitory concentration: 39100 nM
For compound 3 the middle estimate is 2.0-fold (0.29 log units) below the measured one, and the stated range covers the measured number.
By their numbers in this assay, from the lowest: compounds 1, 2 and 3 (each within the scatter of the next).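

In this assay, this is the first change shown at the group on the sulfonyl sulfur, and 4-chloro-2-fluorophenyl in place of 4-fluorophenyl gives a 1.7-fold higher number from compound 1 to compound 3 (0.24 log units; within the scatter). The larger halogenated phenyl is therefore accommodated here with no difference that can be told from the scatter. Nothing available explains this result.

Still open, as far as these compounds go, is how a methyl group or a 4-aminophenyl on the sulfonyl sulfur would read in this assay. From the compounds shown here alone, whether any group at this position can move the number beyond the scatter also remains unknown.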